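Swapping halogens on the fused ring of a kinase-like scaffold

The source may hold more compounds than are shown below. What is called first, only, known or untested is meant among the compounds shown, and "the series" means these compounds.

Of the compounds shown here, three that share one core have been measured in a functional assay on MCF7 cells (Homo sapiens) for antiproliferative activity, read by MTT assay, with a stated time of 48 h; on this read-out higher numbers stand for weaker inhibition and lower numbers for stronger inhibition. Compound 1 `Cc1cnc(Nc2ccc(S(C)(=O)=O)cc2)nc1Nc1nc2ccc(Cl)cc2s1` gives 4320 nM in this assay. Compound 2 `CS(=O)(=O)c1ccc(Nc2nccc(Nc3nc4ccc(F)cc4s3)n2)cc1` reaches only the limit of the assay in this assay, > 60000 nM. Compound 3 `CS(=O)(=O)c1ccc(Nc2nccc(Nc3nc4ccccc4s3)n2)cc1` gives 10600 nM in this assay, the highest number among the two that are numbers; compound 1 sits lower, beyond the scatter, though the two differ in more than one place. For the measured compounds named here, the one step measured in a single place is an at least 5.6-fold lower number from compound 2 to compound 3 (0.75 log units; beyond the scatter), which shows how much removing a fluoro from the fused ring changed matters.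

Compound 4 `CS(=O)(=O)c1ccc(Nc2nccc(Nc3nc4ccc(Cl)cc4s3)n2)cc1` has not been measured. Compared with compound 3 it carries chloro in place of hydrogen on an aromatic carbon. The measured step runs the other way, removing a halogen and lowering the number, so putting a halogen back might raise it; yet compound 1, which carries the same chloro at this place with an extra methyl, gives a lower number than compound 3. Balancing these, compound 4 is expected to show a modest step in this assay, a 1.9-fold lower number from compound 3 to compound 4 (0.28 log units; within the scatter), toward a lower number. The estimate for compound 4 is 5500 nM, with a range from 1500 nM to 25000 nM.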

Compound 4, half-maximal inhibitory concentration: > 50000 nM
Compound 4: a limit, no number; the forecaster's own chance of this, stated with the estimate: 10%; middle value at least 9.0-fold (0.95 log units) away from the limit.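

Compound 4 ends at a limit of the assay, not at a number: the limit of > 50000 nM in this assay, at which 1 of the 4 values shown sits.

Adding the chloro to the six-membered aromatic ring of the fused system in compound 3 therefore brings a clear loss, an at least 4.7-fold higher number from compound 3 to compound 4 (0.67 log units; beyond the scatter), so fluoro and chloro at this place both end in a limit, while hydrogen gives a measured number. Compound 1 goes against any simple rule that a halogen here costs activity: it carries the same chloro, and replacing its methyl with hydrogen on an aromatic carbon gives an at least 11-fold higher number from compound 1 to compound 4 (1.06 log units; beyond the scatter), so among these compounds the cost of the chloro depends on whether that methyl is present.

Which of the two halogens is worse stays open: the step between compound 2 and compound 4 cannot be read, with limits at both ends. Also open, from the compounds shown here alone, is what a methyl does on the shared core without any halogen, and whether a methoxy or an amine in place of the chloro on the fused ring would bring the read-out back to a measurable number.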